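Dichloropyridyl urea series: amide variation on the core

The compounds below may be only part of what the source reports. "The series", "measured", "known", "first", "only" and "open" are said of these compounds alone.

Values in a functional assay on CHO cells for agonist activity at sphingosine 1-phosphate receptor 2 (Homo sapiens), read by fluorescence and calcium flux, with a stated time of 3 min; on this read-out higher numbers stand for weaker inhibition and lower numbers for stronger inhibition:
compound 1 `Cc1cc(C#N)nc(NNC(=O)Nc2cc(Cl)nc(Cl)c2)c1` gives > 23000 nM
compound 2 `Cc1cc(NNC(=O)Nc2cc(Cl)nc(Cl)c2)nc(-c2ccc(F)cc2)c1` gives > 23000 nM
compound 3 `Cc1cc(NNC(=O)Nc2cc(Cl)nc(Cl)c2)nc(C(=O)N(C)C)c1` gives > 23000 nM

Each of these three values is a limit of the assay and not a number. Compound 3 stands at that limit, as do the other two: the limit of > 23000 nM in this assay, at which 3 of the 3 values shown sit. The steps a step that the two limits leave unreadable from compound 1 to compound 3 and a step that the two limits leave unreadable from compound 2 to compound 3 at the same position on the core are therefore of unreadable size, and give no direction.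

Compound 4 `Cc1cc(NNC(=O)Nc2cc(Cl)nc(Cl)c2)nc(C(=O)NC2CC2)c1` differs from compound 3 by cyclopropylamino in place of dimethylamino on a carbonyl carbon. Among the measured compounds shown here, no measured step speaks to this change, and none of the measured steps is readable. The expectation for compound 4 is that it too remains at the limit, with an estimated value of 30000 nM in a range of 8000 nM to 120000 nM. The step that the limit leaves unreadable from compound 3 to compound 4 is expected to lie within the scatter.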

Compound 4, half-maximal inhibitory concentration: > 23000 nM
Compound 4: only a limit was reported; the forecaster's own chance of this, stated with the estimate: 85%; the middle value does not contradict the limit.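

In this assay compound 4 gives > 23000 nM, a limit and not a number, and its steps from compound 1, compound 2 and compound 3 cannot be read: the limit of > 23000 nM in this assay, at which 4 of the 4 values shown sit.

The compounds shown leave open which change on the shared core, if any, gives a measurable value.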